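A Carboxyethyl Chain on a Weak Growth Inhibitor

A few compounds are considered here, and "the series" means these few. Any claim that something is new, unique, unknown or untested is made for them only; others in the source may bear on it.

Compound 1 `CNC(=O)/C=C/c1ccncc1-c1ccc2ccccc2c1` gives 9340 nM
Compound 2 `NC(=O)/C=C/c1ccncc1-c1ccc2ccccc2c1` gives > 10000 nM as a limit of the assay
Compound 3 `CN(C)C(=O)/C=C/c1ccncc1-c1ccc2ccccc2c1` gives 8190 nM

In a functional assay on MCF7 cells (Homo sapiens) for inhibition, read by sulforhodamine B assay, with a stated time of 72 h (a higher number here means a weaker inhibitor of growth, a lower number a stronger inhibitor of growth), compound 3 gives 8190 nM and sits with compound 1 within the usual scatter (a 1.1-fold lower number from compound 1 to compound 3 (0.06 log units; within the scatter)). Going by the values given here, the only other reading is that limit for compound 2.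

Compound 4 `O=C(O)CCc1ccncc1-c1ccc2ccccc2c1` has not yet been measured. The change is 2-carboxyethyl in place of 2-(dimethylcarbamoyl)ethenyl on an aromatic carbon with 2-carboxyethyl in place of 2-(dimethylcarbamoyl)ethenyl on an aromatic carbon, ortho to a large group and opposite the ring nitrogen.

The measured steps bear on this only loosely. They alter just the substituents on the amide-type nitrogen (an at least 1.0-fold higher number from compound 1 to compound 2 (0.02 log units; that floor lies within the scatter) and an at least 1.2-fold lower number from compound 2 to compound 3 (0.08 log units; that floor lies within the scatter) along with the step above) and none replaces the whole chain. All stay within the scatter, so no step beyond it is expected in this assay, with a slight lean towards a higher number. The expected step is a 1.3-fold higher number from compound 3 to compound 4 (0.13 log units; within the scatter) and a reading at the assay limit is quite possible. For compound 4 the estimate is 11000 nM with an expected range from 5500 nM to 22000 nM in this assay.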

Compound 4, concentration for 50% growth inhibition: > 10000 nM
Compound 4 was reported as a limit; the forecaster's own chance of this, stated with the estimate: 60%; the middle value does not contradict the limit.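

Replacing the whole side chain at this position, rather than only the substituents on the amide-type nitrogen, gives an at least 1.2-fold higher number from compound 3 to compound 4 (0.08 log units; that floor lies within the scatter) and an at least 1.0-fold higher number from compound 1 to compound 4 (0.02 log units; that floor lies within the scatter) in this assay. Going by these compounds alone, neither floor shows a real difference, so even this larger change, from an amide chain with a double bond to a saturated carboxylic acid chain, gives no clear separation from the earlier compounds. The step between compound 2 and compound 4 cannot be read, and compound 4 adds a second reading at the limit: the limit of > 10000 nM in this assay, at which 2 of the 4 values shown sit.

Compound 4 changes the chain's double bond and its end group together, so the effect of each stays unresolved. Also open, on these data alone, is whether an amine at the end of the chain, or a longer chain, would give a reading clearly below the limit.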